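A few compounds are considered here, and "the series" means these few. Any claim that something is new, unique, unknown or untested is made for them only; others in the source may bear on it.

Measured compounds in an assay on CHO cells for displacement of a labelled ligand from adenosine receptor A3 (Homo sapiens), read by radioligand binding; on this read-out lower numbers stand for stronger inhibition and higher numbers for weaker inhibition:

- compound 1 `O=c1oc2c(O)cccc2cc1-c1ccccc1` gives 5090 nM
- compound 2 `O=c1oc2c(O)c(O)ccc2cc1-c1ccccc1` gives 3850 nM
- compound 3 `O=c1oc2c(O)cccc2cc1-c1ccc(O)c(O)c1` gives 23600 nM

Compound 2 differs from compound 1 by hydroxy in place of hydrogen on an aromatic carbon. That change barely moved the number: a 1.3-fold lower number from compound 1 to compound 2 (0.12 log units; within the scatter). Compound 3 carries a different core; how its core differs from that of compound 1 is not broken down here. In this assay compound 3 shows the highest number of the three, with gaps to compound 1 and to compound 2 that lie beyond the usual scatter.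

Compound 4 `O=c1oc2c(O)c(O)ccc2cc1-c1ccc(O)c(O)c1` is not yet measured. Among the measured compounds shown here, it differs from compound 3 by hydroxy in place of hydrogen on an aromatic carbon, the same change, in the same surroundings, as the one separating compound 1 from compound 2. For the measured compounds named here, only that one earlier instance exists, so the expectation rests on it alone. Only a small step is expected for compound 4, a 1.3-fold lower number from compound 3 to compound 4 (0.12 log units; within the scatter), because the same change earlier gave a 1.3-fold lower number from compound 1 to compound 2 (0.12 log units; within the scatter). The estimate for compound 4 in this assay is 18000 nM, expected to fall between 7000 nM and 45000 nM.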

Compound 4, inhibition constant: 8500 nM
The estimate for compound 4 lay 2.1-fold (0.33 log units) above the measured number; measured number inside the range.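

In this assay, hydroxy in place of hydrogen on an aromatic carbon, ortho to a hydroxy group, gave a 2.8-fold lower number from compound 3 to compound 4 (0.44 log units; beyond the scatter). Set beside the earlier step, the change carries across the two cores without a difference that can be told from the scatter: the same change on two cores in this assay, a 1.3-fold lower number (0.12 log units; within the scatter) from compound 1 to compound 2 and a 2.8-fold lower number (0.44 log units; beyond the scatter) from compound 3 to compound 4, 2.1-fold (0.32 log units) apart, within the scatter of two such steps. This supports expecting a similar, small lowering of the number when the change is moved between these two cores, but it rests on two pairs only, one step lying within the scatter and the other beyond it, and it fixes neither an exact size for the step nor its behaviour on any other core.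

The compounds shown leave open whether a methoxy group, a fluorine atom or an amine on the same aromatic carbon would move the number as hydroxy does. They also leave open how the hydroxy step reads on a core bearing a carboxylic acid or a longer chain.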